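Changing the Group on the Aromatic Oxygen

The source may hold more compounds than are shown below. What is called first, only, known or untested is meant among the compounds shown, and "the series" means these compounds.

In an assay on CHO cells for displacement of a labelled ligand from adenosine receptor A3 (Homo sapiens), read by scintillation counting, tested at 10 uM (on this read-out higher numbers stand for more inhibition at the one concentration tested (going by the name of the read-out) and lower numbers for less inhibition), the three measured compounds gave these numbers:
compound 1 `CC(C)(C)Cc1c(/C=C/c2ccc(Cl)cc2)sc(N)c1C(=O)c1ccc(Cl)cc1`: 11%
compound 2 `COCCOc1ccc(-c2sc(N)c(C(=O)c3ccc(Cl)cc3)c2CC(C)(C)C)cc1`: 1%
compound 3 `CC(C)(C)Cc1c(-c2ccc(OC(F)(F)F)cc2)sc(N)c1C(=O)c1ccc(Cl)cc1`: 1%

Compound 3 is level with compound 2, and together they are the lowest of the three numbers; compound 1 lies a little higher, within the usual scatter. Compound 4 `COc1ccc(-c2sc(N)c(C(=O)c3ccc(Cl)cc3)c2CC(C)(C)C)cc1` differs from compound 3 in one place: methyl in place of trifluoromethyl on an oxygen on an aromatic ring. Within the data shown here, one measured step touches the same spot: no change at the digits printed from compound 2 to compound 3 (within the scatter). Among the measured compounds shown here, no measured step compares trifluoromethyl with methyl, so the expectation rests on that single step, in which exchanging the group on this oxygen left the number unchanged. The same is expected here, with a number 1 percentage points higher from compound 3 to compound 4 (within the scatter). Compound 4 is therefore estimated at 2%, between -8% and 12%.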

Compound 4, a percentage reported as inhibition, at one concentration (the size of the read-out at that concentration, not a potency): 2%
The estimate for compound 4 equals the measured number at the digits printed; the range from low to high includes it.
By their numbers in this assay, from the lowest: compounds 2, 3, 4 and 1 (each within the scatter of the next).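

In this assay, a third group on the oxygen on the aromatic ring now reads like the other two: methyl in place of trifluoromethyl gives a number 1 percentage points higher from compound 3 to compound 4 (within the scatter) and, set against 2-methoxyethyl, a number 1 percentage points higher from compound 2 to compound 4 (within the scatter) on the same oxygen. Exchanging the whole 2-(4-chlorophenyl)ethenyl for 4-methoxyphenyl on the aromatic carbon gives a number 9 percentage points lower from compound 1 to compound 4 (within the scatter) and so also stays within the scatter. These compounds therefore show no group at either place that separates from the rest.

As far as these compounds go, whether an amine or a carboxylic acid on that aromatic ring would give a clearly different number remains open. No independent evidence bears on these results.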